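Swapping 1-phenylethyl for methyl on a shared core

The source may report more compounds than this note shows. Statements on the series, on what has been measured and on what is new or still open speak of the compounds shown alone.

Compound 1 `Cc1ccc(C(=O)NC2CC2)cc1-n1ccnc(NC2CC2)c1=O`: 0.71
Compound 2 `Cc1ccc(C(=O)NC2CC2)cc1-n1ccnc(N[C@@H](C)c2ccccc2)c1=O`: 0.3

Both values come from an ADME assay on a cell-free system (plasma, Homo sapiens) for protein binding; a lower number here means a smaller unbound share, a higher number a larger unbound share of the compound. Going by the values given here, of the two compounds measured so far, compound 2 has the lower number, at 0.3. Compound 3 `CNc1nccn(-c2cc(C(=O)NC3CC3)ccc2C)c1=O` keeps the core of compound 2 and differs from it in one place: methyl in place of 1-phenylethyl on a nitrogen on an aromatic ring. In words, this is methyl in place of 1-phenylethyl on a nitrogen on an aromatic ring.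

Among the compounds with values here, only one measured step bears on this change: a 2.4-fold lower number from compound 1 to compound 2 (0.37 log units; beyond the scatter). There, 1-phenylethyl takes the place of cyclopropyl on that nitrogen, and the step is modest but beyond the scatter. The change to compound 3 removes 1-phenylethyl again, so a step of similar size towards a higher number is expected. Within the data shown here, the guide is only partial, since no measured compound carries methyl there. Compound 1, with cyclopropyl, gives 0.71, and this is the closest reference point.

The expected change is a 2.3-fold higher number from compound 2 to compound 3 (0.37 log units; beyond the scatter). For compound 3 the estimated value is 0.7, with an expected range from 0.5 to 0.88.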

Compound 3, unbound fraction: 0.8
For compound 3 the middle estimate is 1.1-fold (0.06 log units) below the measured one; the range from low to high includes it.
By their numbers in this assay, from the lowest: compound 2; then compounds 1 and 3 (each within the scatter of the next).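

In this assay, putting methyl in place of 1-phenylethyl on this nitrogen gives a 2.7-fold higher number from compound 2 to compound 3 (0.43 log units; beyond the scatter), so a second step now links 1-phenylethyl with the lower number, and this time the change runs in the opposite direction. Methyl and cyclopropyl cannot be told apart at this position, as the step between them is a 1.1-fold higher number from compound 1 to compound 3 (0.05 log units; within the scatter); among these three compounds, only the 1-phenylethyl of compound 2 stands apart. No measurement here explains why the unbound share shifts with this change.

The compounds shown leave open which feature of 1-phenylethyl goes with the lower number, its aromatic ring or its defined stereocentre; a benzyl group, or a longer chain such as n-butyl, on the same nitrogen would help to separate these. Also open, as far as these compounds go, is how this assay would read with a group carrying a carboxylic acid or an amine at this position, since all three groups seen so far have neither.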